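Swapping the trifluoromethyl for fluoro on the fluorinated ring

A few compounds are considered here, and "the series" means these few. Any claim that something is new, unique, unknown or untested is made for them only; others in the source may bear on it.

Measured so far:
compound 1 `CCc1nc(Cl)c2n1CCN([C@@H](C(=O)NC)c1ccccc1)[C@H]2COc1ccc(C(F)(F)F)cc1` — 9 nM
compound 2 `CCc1nc(Cl)c2n1CCN([C@@H](C(=O)NC)c1ccccc1)[C@H]2CCc1ccc(C(F)(F)F)cc1F` — 12 nM
compound 3 `CCc1nc(Cl)c2n1CCN([C@@H](C(=O)NC)c1ccccc1)[C@H]2CCc1ccc(C(F)(F)F)c(F)c1F` — 14 nM

All three were tested in a functional assay on CHO cells for antagonist activity at Orexin receptor type 2 (Homo sapiens), read by FLIPR and calcium flux; a higher number here means a weaker inhibitor, a lower number a stronger inhibitor. Compound 3 has the highest number of the three, but its gap to compound 2 and to compound 1 is within the scatter, so the three cannot be put in order on these figures. The step of a 1.3-fold higher number from compound 1 to compound 2 (0.12 log units; within the scatter) exchanged the phenoxy link for a benzyl link with an added fluoro, and the step of a 1.2-fold higher number from compound 2 to compound 3 (0.07 log units; within the scatter) added a second fluoro on the same ring; neither moved the number beyond the scatter.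

Compound 4 `CCc1nc(Cl)c2n1CCN([C@@H](C(=O)NC)c1ccccc1)[C@H]2CCc1ccc(F)c(F)c1F` differs from compound 3 in one place: fluoro in place of trifluoromethyl on an aromatic carbon. Among the compounds with values here, no measured step touches this trifluoromethyl group; it is present in compound 1, compound 2 and compound 3 alike, so the measured steps give no direct guide. The two steps that do exist changed the same ring and its link without shifting the number, which argues against a large jump, but a group of several atoms is lost here, and a modest weakening is expected, as the step of a 2.9-fold higher number from compound 3 to compound 4 (0.46 log units; beyond the scatter) expresses. Compound 4 is therefore estimated at 40 nM in this assay, with a range from 12 nM to 150 nM.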

Compound 4, half-maximal inhibitory concentration: 5 nM
Estimate against measurement, compound 4: 8.0-fold (0.90 log units) above; measured number outside the range, below it.
By their numbers in this assay, from the lowest: compounds 4, 1, 2 and 3 (each within the scatter of the next, the first and the last beyond it).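

In this assay, within the data shown here, the trifluoromethyl group at this place on the ring turns out not to be required: replacing it with a single fluoro, a group of one heavy atom instead of four, gives a 2.8-fold lower number from compound 3 to compound 4 (0.45 log units; beyond the scatter) and is the first change here to move the number beyond the scatter. Compound 4 also separates from the other compound with the same chain, with a 2.4-fold lower number from compound 2 to compound 4 (0.38 log units; beyond the scatter) being beyond the scatter, while a 1.8-fold lower number from compound 1 to compound 4 (0.26 log units; within the scatter) remains within it, so compound 1 and compound 4 cannot be put in order. No measurement available here accounts for this shift.

As far as these compounds go, it remains open whether the result comes from having fluoro at this place or simply from removing trifluoromethyl, a question that plain hydrogen, chloro or methoxy on the same carbon would help to settle. Also unresolved is whether the same swap would act in the same way on the 4-(trifluoromethyl)phenoxy group of compound 1, where a 4-fluorophenoxy group would be the direct comparison.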